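Swapping a Para-Ethyl for a Meta-Methyl on the Aryl Ring

A few compounds are considered here, and "the series" means these few. Any claim that something is new, unique, unknown or untested is made for them only; others in the source may bear on it.

Measured so far:
compound 1, `O=Cc1ccc(-c2cn3ccnc3c(-c3ccc4ncn(C5CCCCC5)c4c3)n2)cc1`, 23.1%
compound 2, `CCc1ccc(-c2cn3ccnc3c(-c3ccc4ncn(Cc5ccccc5)c4c3)n2)cc1`, 51.2%

Both compounds were tested in a functional assay on SF-295 cells (Homo sapiens) for inhibition, read by sulforhodamine B assay, with a stated time of 48 h, tested at 10 uM; on this read-out higher numbers stand for more inhibition at the one concentration tested (going by the name of the read-out) and lower numbers for less inhibition. Compound 2 stands highest of the two numbers; its value is above that of compound 1 by more than the usual scatter. Among the measured compounds shown here, the two differ in more than one place, so no single step between them can be read off.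

Compound 3, `Cc1cccc(-c2cn3ccnc3c(-c3ccc4ncn(Cc5ccccc5)c4c3)n2)c1`, has not yet been measured. It departs from compound 2 in one spot: 3-methylphenyl in place of 4-ethylphenyl on an aromatic carbon. The change keeps the ring and only moves and shortens the alkyl group, with no new donors or acceptors.

For the measured compounds named here, no measured pair isolates such a change, so the step of a number 8.2 percentage points lower from compound 2 to compound 3 (within the scatter) is expected to be small and probably downward, but within the scatter. Compound 3 is therefore estimated at 43%, with a range from 22% to 64%.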

Compound 3, a percentage reported as inhibition, at one concentration (the size of the read-out at that concentration, not a potency): 14.3%
For compound 3 the middle estimate is 28.7 percentage points above the measured one, and the stated range ends above it.
By their numbers in this assay, from the lowest: compounds 3 and 1 (each within the scatter of the next); then compound 2.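

In this assay, among the compounds shown here, putting 3-methylphenyl in place of 4-ethylphenyl on this aromatic carbon of the shared core gives a number 36.9 percentage points lower from compound 2 to compound 3 (beyond the scatter), the first step in this set that can be read at a single place. It shows that the inhibition read here can depend strongly on the alkyl group on this phenyl ring, even though the ring itself stays and the count of hydrogen-bond donors and acceptors does not change. Nothing available explains why the number falls.

This one step changes the position and the length of the alkyl group together, and the compounds shown do not separate those two changes. Going by these compounds, how a longer chain, an amine or a carboxylic acid on this phenyl ring would read in this assay also remains open.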